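A few compounds are considered here, and "the series" means these few. Any claim that something is new, unique, unknown or untested is made for them only; others in the source may bear on it.

Measured compounds in a functional assay, read by spectrophotometry, with a stated time of 30 min; a higher number here means that more compound is needed for the effect, a lower number that less compound is needed:

Compound 1 `COc1cc(C2Oc3cc([C@H]4Oc5cc(O)cc(O)c5C(=O)[C@@H]4O)ccc3OC2COC(=O)c2cc(OC)c(OC)c(OC)c2)ccc1O`: compound 1 gives 94800 nM.
Compound 2 `COc1cc(C2Oc3cc([C@H]4Oc5cc(O)cc(O)c5C(=O)[C@@H]4O)ccc3OC2COC(=O)c2ccc([N+](=O)[O-])cc2)ccc1O`: compound 2 gives > 300000 nM, a limit of this assay rather than a number.
Compound 3 `COc1cc(C2Oc3cc([C@H]4Oc5cc(O)cc(O)c5C(=O)[C@@H]4O)ccc3OC2COC(=O)c2cc([N+](=O)[O-])cc([N+](=O)[O-])c2)ccc1O`: compound 3 gives 205000 nM.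

Of the two numbers in this assay, compound 3 stands highest; its nearest neighbour is compound 1, with a 2.2-fold higher number from compound 1 to compound 3 (0.33 log units; beyond the scatter). The comparison with compound 2 rests on a limit of > 300000 nM in this assay, at which 1 of the 3 values shown sits, and yields only an at least 1.4-fold lower number from compound 2 to compound 3 (0.16 log units; that floor lies within the scatter). Going by the values given here, the series so far varies only the aryl group on the ester carbonyl.

Compound 4 `COc1cc(C2Oc3cc([C@H]4Oc5cc(O)cc(O)c5C(=O)[C@@H]4O)ccc3OC2COC(=O)/C=C/c2ccc(Cl)cc2)ccc1O` differs from compound 3 by 2-(4-chlorophenyl)ethenyl in place of 3,5-dinitrophenyl on a carbonyl carbon. Among the compounds with values here, no measured step replaces an aryl ester with an aryl-ethenyl ester, so none bears directly on this change. The steps seen among the aryl esters were an at least 3.1-fold higher number from compound 1 to compound 2 (0.50 log units; beyond the scatter) and a 2.2-fold higher number from compound 1 to compound 3 (0.33 log units; beyond the scatter), both in the direction of a higher number when nitro groups replace methoxy groups; the new group carries neither. In this assay compound 4 is therefore expected to give a number near those already seen, and the step of a 1.7-fold lower number from compound 3 to compound 4 (0.23 log units; within the scatter) is expected to stay within the scatter. The estimate for compound 4 is 120000 nM, with a range from 40000 nM to 300000 nM.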

Compound 4, half-maximal effective concentration: 87900 nM
The estimate for compound 4 lay 1.4-fold (0.14 log units) above the measured number; low and high end bracket the measured number.
By their numbers in this assay, from the lowest: compounds 4 and 1 (each within the scatter of the next); then compound 3. At a limit, above all of these: compound 2.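

In this assay, the position on the carbonyl carbon also takes 2-(4-chlorophenyl)ethenyl, a group with an ethenyl link and neither nitro nor methoxy groups, and the reading stays level with the trimethoxy ester: a 1.1-fold lower number from compound 1 to compound 4 (0.03 log units; within the scatter). Against the dinitro ester the same group gives a step beyond the scatter, a 2.3-fold lower number from compound 3 to compound 4 (0.37 log units; beyond the scatter), so the gap between compound 1 and the nitro-bearing esters now also separates those esters from a group of a different kind. Against the 4-nitrophenyl ester the step is only a floor, an at least 3.4-fold lower number from compound 2 to compound 4 (0.53 log units; beyond the scatter), as compound 2 stands at a limit and not at a number: the limit of > 300000 nM in this assay, at which 1 of the 4 values shown sits.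

The compounds shown leave open whether the ethenyl link or the chlorine decides the reading of compound 4, as the two enter together, and a plain 2-phenylethenyl group or a 4-chlorophenyl group directly on the carbonyl would separate them. Also open, as far as these compounds go, is how an amine or a carboxylic acid on the aromatic ring, or an amide in place of the ester, would read in this assay.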